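The source may hold more compounds than are shown below. What is called first, only, known or untested is meant among the compounds shown, and "the series" means these compounds.

Measured in an ADME assay on Vero cells (Chlorocebus sabaeus) for cytotoxicity, read by MTT assay; on this read-out higher numbers stand for weaker inhibition and lower numbers for stronger inhibition
compound 1 `CCC(CC)C(=O)OCC(C)(C)CC1=C(O)C(=O)c2ccccc2C1=O` gives 104000 nM
compound 2 `CCC(C)CC(=O)OCC(C)(C)CC1=C(O)C(=O)c2ccccc2C1=O` gives 2300 nM
compound 3 `CCCCCCCCC(=O)OCC(C)(C)CC1=C(O)C(=O)c2ccccc2C1=O` gives 150000 nM

Compound 3 stands at the high end of this small set, but it does not stand alone there, since a 1.4-fold higher number from compound 1 to compound 3 (0.16 log units; within the scatter) stays within the scatter. Its other neighbour is far away, and a 65-fold higher number from compound 2 to compound 3 (1.81 log units; beyond the scatter) is a large step.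

Compound 4 `CCCCCCCCCCCCCCCCCC(=O)OCC(C)(C)CC1=C(O)C(=O)c2ccccc2C1=O` has not been measured yet. It keeps the shared core and extends the octyl chain of compound 3, and the change reads (nonyl in place of hydrogen on a saturated chain carbon, eight bonds along the chain from a carbonyl carbon).

Among the measured compounds shown here, no measured step lengthens a straight chain, so the evidence is indirect. The closest case is a 1.4-fold higher number from compound 1 to compound 3 (0.16 log units; within the scatter), which swaps pentan-3-yl for octyl and moves nothing beyond the scatter. A warning comes from a 45-fold lower number from compound 1 to compound 2 (1.66 log units; beyond the scatter), a large step between two small groups, which shows that this set can jump. Compound 3, at 150000 nM, remains the nearest guide, so no step beyond the scatter is expected in this assay. The estimated move is a 1.3-fold lower number from compound 3 to compound 4 (0.10 log units; within the scatter). Compound 4 is expected at 120000 nM, with an estimated range from 30000 nM to 400000 nM.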

Compound 4, half-maximal inhibitory concentration: 15500 nM
For compound 4 the middle estimate is 7.7-fold (0.89 log units) above the measured one; the whole stated range lies above it.
By their numbers in this assay, from the lowest: compound 2; then compound 4; then compounds 1 and 3 (each within the scatter of the next).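

In this assay, the added nonyl, on a saturated chain carbon eight bonds along the chain from a carbonyl carbon, gives a 9.7-fold lower number from compound 3 to compound 4 (0.99 log units; beyond the scatter) and so moves the number beyond the scatter. This is the first step shown that only lengthens a straight chain, and it shows that the far end of this chain still affects the read-out, which the swap of pentan-3-yl for octyl, with a 1.4-fold higher number from compound 1 to compound 3 (0.16 log units; within the scatter) inside the scatter, gave no sign of. No measurement offered here accounts for the fall, so the data record the change without explaining it.

The compounds shown leave open how the number behaves for straight chains of intermediate length, such as a dodecyl group on the carbonyl carbon, and so whether it falls gradually or in one sudden drop somewhere along the way. Among the compounds shown here, they also leave open what a chain ending in a carboxylic acid or an amine would do at this same far end, and whether a branched chain as long as the one in compound 4 would behave like it.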